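From ((dimethylamino)methyl)carbonyl to dimethylsulfamoyl on a shared core

The source may hold more compounds than are shown below. What is called first, only, known or untested is meant among the compounds shown, and "the series" means these compounds.

Compound 1: `CCCCn1c(=O)n(Cc2ccccc2F)c(=O)c2[nH]c(Cc3ccc(NC(C)=O)cc3)nc21` — 2110 nM
Compound 2: `CN(C)CC(=O)Nc1ccc(Cc2nc3c([nH]2)c(=O)n(Cc2ccccc2F)c(=O)n3CC2CC2)cc1` — 2070 nM

Of the compounds shown here, two have been tested in an assay on isolated protein for inhibition of phosphoenolpyruvate carboxykinase, cytosolic [GTP] (Homo sapiens); on this read-out higher numbers stand for weaker inhibition and lower numbers for stronger inhibition. Compound 1 gives 2110 nM and compound 2 gives 2070 nM. The two numbers are within the scatter of each other, so neither compound can be called the stronger inhibitor; they simply sit in the same range. Compound 2 is the starting point for the next step.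

Within the data shown here, compound 3, `CN(C)S(=O)(=O)Nc1ccc(Cc2nc3c([nH]2)c(=O)n(Cc2ccccc2F)c(=O)n3CC2CC2)cc1`, keeps the whole core of compound 2 and changes only one group: dimethylsulfamoyl in place of ((dimethylamino)methyl)carbonyl on a nitrogen on an aromatic ring. Among the measured compounds shown here, no measured pair in this set shows what such a swap does, so the expectation for compound 3 rests on the fact that compound 2 and compound 1 land in the same range in this assay and that the group entering is the same size as the group leaving.

The step from compound 2 to compound 3 is expected to be small, a 1.2-fold higher number from compound 2 to compound 3 (0.08 log units; within the scatter), with no change beyond the scatter.

Compound 3 is therefore estimated at 2500 nM, in a range from 900 nM to 7000 nM.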

Compound 3, half-maximal inhibitory concentration: 960 nM
The estimate for compound 3 lay 2.6-fold (0.42 log units) above the measured number, and the stated range covers the measured number.
By their numbers in this assay, from the lowest: compound 3; then compounds 2 and 1 (each within the scatter of the next).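

In this assay, the group on the nitrogen on an aromatic ring now proves able to shift the number: dimethylsulfamoyl in place of ((dimethylamino)methyl)carbonyl gives a 2.2-fold lower number from compound 2 to compound 3 (0.33 log units; beyond the scatter), a modest step towards stronger inhibition and the first one here that can be tied to a single place, as compound 1 and compound 2 differ in more than one. Both groups have 6 heavy atoms, 2 hydrogen-bond acceptors and no net charge, so these counts stay the same, while the make-up changes: a sulfur enters, and the group has 2 double bonds outside aromatic rings rather than 1. No measurement available here accounts for the step.

From the compounds shown here alone, it remains open whether the dimethylamino end of the dimethylsulfamoyl group matters, which a methanesulfonyl group on the same nitrogen could test, and whether a larger diethylsulfamoyl group would keep the step. Going by these compounds, it is also open whether the same swap would give a similar step on the core of compound 1, which carries a butyl chain where compound 3 carries cyclopropylmethyl.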